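This account rests on a few compounds, and the source may have more. Where it says the series, first, only, none or still open, it means among the compounds named here.

Compound 1 (`O=C(CCCCCNc1c(NCc2ccccc2)c(=O)c1=O)NO`): 75000000 nM
Compound 2 (`CC[C@H](Nc1c(NCCCCCC(=O)NO)c(=O)c1=O)c1ccccc1`): 75000000 nM
Compound 3 (`Cc1ccccc1[C@H](C)Nc1c(NCCCCCC(=O)NO)c(=O)c1=O`): 92000000 nM

In a physicochemical assay for solubility, read by HPLC, in phosphate buffer, with a stated time of 24 h, at pH 7.4, tested at 100 uM (on this read-out lower numbers stand for lower solubility and higher numbers for higher solubility), compound 1 gives 75000000 nM and is level with compound 2, while compound 3 lies within the usual scatter of both.

Compound 4 (`O=C(CCCCCNc1c(NC2CCCCC2)c(=O)c1=O)NO`) has not yet been measured. It carries cyclohexyl in place of benzyl on a nitrogen on an aromatic ring. A non-aromatic ring therefore enters where an aromatic one leaves.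

Within the data shown here, only one measured step offers any guidance, and it changes a different place: ethyl in place of hydrogen on a saturated chain carbon bound to an aromatic carbon and a nitrogen on an aromatic ring (no change at the digits printed from compound 1 to compound 2 (within the scatter)). Among the measured compounds shown here, no measured compound carries cyclohexyl, so this evidence is indirect and the range must stay wide.

On this evidence, no change beyond the scatter is expected in this assay (a 1.1-fold lower number from compound 1 to compound 4 (0.03 log units; within the scatter)). Compound 4 is estimated at 70000000 nM, with an expected range from 40000000 nM to 100000000 nM (an estimate, not a measurement).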

Compound 4, solubility: 91000000 nM
Compound 4: the middle estimate sits 1.3-fold (0.11 log units) below what was measured; measured number inside the range.
By their numbers in this assay, from the lowest: compounds 1, 2, 4 and 3 (each within the scatter of the next).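

In this assay, compound 1, compound 2 and compound 3 all keep an aromatic ring in this part of the molecule, so they could not show whether that ring matters to the read-out. Cyclohexyl in place of benzyl on a nitrogen on an aromatic ring is the first change that removes it, and it gives a 1.2-fold higher number from compound 1 to compound 4 (0.08 log units; within the scatter), so here a non-aromatic ring of carbon only serves as well as an aromatic one. Nothing available explains this result.

On these data alone, both rings contain carbon only, so it remains open whether a ring carrying an amine or a carboxylic acid would also stay within the scatter. All four numbers also lie close to the tested concentration, so this read-out may not reveal differences among compounds this soluble.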